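The compounds below may be only part of what the source reports. "The series", "measured", "known", "first", "only" and "open" are said of these compounds alone.

Of the compounds shown here, two of the shared core have been measured in a functional assay on MT4 cells (Homo sapiens); on this read-out lower numbers stand for higher toxicity in this test and higher numbers for lower toxicity in this test. Compound 1, with the structure `O=c1nc(/N=C/N(c2ccc(F)cc2)c2ccc(F)cc2)ccn1C1CSC(CO)O1`, gives in this assay 150000 nM. Compound 2, with the structure `CN(C)/C=N/c1ccn(C2CSC(CO)O2)c(=O)n1`, carries a dimethylamino group on the carbon with a double bond to nitrogen; for compound 2 this assay reports only a limit, > 440000 nM, so no number is known for it. Compound 2 therefore stands at the upper edge of what the test can report, and this is the limit of > 440000 nM in this assay, at which 1 of the 2 values shown sits. Among the measured compounds shown here, the values of compound 1 and compound 2 are all that can be said of the pair, and no measured step between them is available.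

Compound 3, with the structure `O=c1nc(/N=C/N2CCOCC2)ccn1C1CSC(CO)O1`, has not yet been measured in this assay. It differs from compound 2 by morpholin-4-yl in place of dimethylamino on a carbon with a double bond to nitrogen. With only the limit of compound 2 to go on, the expected step of an at least 1.1-fold lower number from compound 2 to compound 3 (0.04 log units; that floor lies within the scatter) is none beyond the scatter. Compound 3 is thus estimated at 400000 nM, with a range from 150000 nM to 1000000 nM, and a further limit rather than a number is considered the likelier outcome.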

Compound 3, half-maximal cytotoxic concentration in the MT4 assay: > 265000 nM
Compound 3 was reported as a limit; the forecaster's own chance of this, stated with the estimate: 60%; the middle value lies beyond the limit too.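

Among the compounds shown here, in the MT4 assay, compound 2 and compound 3 are each reported only as a limit, and no step between them can be read. In a physicochemical assay for lipophilicity (on this read-out lower numbers stand for lower lipophilicity and higher numbers for higher lipophilicity), compound 2 gives 1.02 and compound 3 gives 0.62. The compounds shown leave open whether morpholin-4-yl in place of dimethylamino changes the result in the MT4 assay at all.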